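Moving the methyl on the sulfonamide ring

The source may hold more compounds than are shown below. What is called first, only, known or untested is meant among the compounds shown, and "the series" means these compounds.

Two close relatives of the same shared core have been measured in a functional assay on 143B cells (Homo sapiens) for antiproliferative activity, read by MTT assay, with a stated time of 48 h; a lower number here means a stronger inhibitor, a higher number a weaker inhibitor. Compound 1 `O=C(/C=C/c1cccc(NC(=O)c2ccccc2Cl)c1)c1nc2ccccc2[nH]1` carries a (2-chlorophenyl)carbonyl on the ring nitrogen and gives 3690 nM. Compound 2 `Cc1ccccc1S(=O)(=O)Nc1cccc(/C=C/C(=O)c2nc3ccccc3[nH]2)c1` carries a (2-methylphenyl)sulfonyl there instead and gives 4060 nM. Among the measured compounds shown here, the single measured step, a 1.1-fold higher number from compound 1 to compound 2 (0.04 log units; within the scatter), changes nothing beyond the scatter, and compound 2 therefore stands with the highest of the two numbers while its only neighbour, compound 1, sits within the scatter of it.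

Compound 3 `Cc1ccc(S(=O)(=O)Nc2cccc(/C=C/C(=O)c3nc4ccccc4[nH]3)c2)cc1` differs from compound 2 by 4-methylphenyl in place of 2-methylphenyl on a sulfonyl sulfur. For the measured compounds named here, no measured step moves a methyl around a ring; the one step recorded swaps a whole group on the nitrogen, and that step, a 1.1-fold higher number from compound 1 to compound 2 (0.04 log units; within the scatter), stayed within the scatter. Nothing in these numbers points to a shift in either direction for this assay, so the expected step is a 1.0-fold lower number from compound 2 to compound 3 (0.01 log units; within the scatter). Compound 3 is therefore estimated to give 4000 nM in this assay, with a range from 1500 nM to 11000 nM.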

Compound 3, half-maximal inhibitory concentration: 3220 nM
Beside the measured number, compound 3's estimate is 1.2-fold (0.09 log units) above it; measured number inside the range.
By their numbers in this assay, from the lowest: compounds 3, 1 and 2 (each within the scatter of the next).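

In this assay, the methyl on the ring held by the sulfonyl sulfur can now be compared in two placements, and 4-methylphenyl in place of 2-methylphenyl gives a 1.3-fold lower number from compound 2 to compound 3 (0.10 log units; within the scatter), so this move of a single methyl leaves no readable difference. The larger swap on the nitrogen, (4-methylphenyl)sulfonyl in place of (2-chlorophenyl)carbonyl, gives a 1.1-fold lower number from compound 1 to compound 3 (0.06 log units; within the scatter), which confirms with a second sulfonyl compound what the first swap showed: the carbonyl and sulfonyl forms shown here cannot be told apart by these numbers. No accompanying measurement offers any explanation for this flat picture.

As far as these compounds go, whether that picture would survive a real change on the same ring, such as an amine or a carboxylic acid in place of the methyl, or a longer chain, stays open. Equally open, from the compounds shown here alone, is what a plain methylsulfonyl on the nitrogen would give, with no aromatic ring on the sulfur at all.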